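A few compounds are considered here, and "the series" means these few. Any claim that something is new, unique, unknown or untested is made for them only; others in the source may bear on it.

Measured in a functional assay on K562 cells (Homo sapiens) for inhibition, read by sulforhodamine B assay, with a stated time of 48 h; a lower number here means a stronger inhibitor of growth, a higher number a weaker inhibitor of growth:

compound 1 `Nc1cc(N)c2nc(-c3ccccc3)c(Oc3ccc(Cl)c(Cl)c3)nc2c1`: 3550 nM
compound 2 `CCOC(=O)[C@H](CCC(=O)O)NC(=O)c1ccc(CNc2nc3cc(N)cc(N)c3nc2-c2ccccc2)cc1`: 8710 nM
compound 3 `COc1cc(CNc2nc3cc(N)cc(N)c3nc2-c2ccccc2)cc(OC)c1OC`: 1780 nM

Three compounds share a core, each carrying a different group on the carbon that is ortho to the phenyl group. Compound 1 sits second highest of the three numbers. Its nearest neighbour is compound 3, whose number in this assay lies within the scatter of that of compound 1, so no order between the two can be read. Compound 2, with its substituted benzylamino group, gives a number beyond the scatter above compound 1, the only difference among the three that counts as a difference.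

Compound 4 `Nc1cc(N)c2nc(-c3ccccc3)c(Sc3ccc(F)cc3)nc2c1` has not been measured. It differs from compound 1 in one place: (4-fluorophenyl)sulfanyl in place of 3,4-dichlorophenoxy on an aromatic carbon. Among the measured compounds shown here, no measured pair in this set shares this kind of change, so no step size is available from the series itself. The expectation is therefore that the step from compound 1 to compound 4 stays close to the scatter, with no firm direction; the expected step is a 1.0-fold lower number from compound 1 to compound 4 (0.01 log units; within the scatter). Compound 4 is estimated in this assay at 3500 nM, with a range from 1200 nM to 10000 nM, the width reflecting that only compound 1 anchors it.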

Compound 4, concentration for 50% growth inhibition: 39800 nM
Beside the measured number, compound 4's estimate is 11-fold (1.06 log units) below it, and the stated range ends below it.
By their numbers in this assay, from the lowest: compounds 3 and 1 (each within the scatter of the next); then compound 2; then compound 4.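

This position, on an aromatic carbon next to the ring nitrogen and ortho to a phenyl group, is sensitive to the exchange of one aromatic group for another: in this assay, (4-fluorophenyl)sulfanyl in place of 3,4-dichlorophenoxy gives an 11-fold higher number from compound 1 to compound 4 (1.05 log units; beyond the scatter). Among the compounds shown here, the earlier compounds included no pair differing in one place, so this is the first step whose size can be read, and it shows that the two groups are not interchangeable here, even though each holds one six-membered aromatic ring of carbon only and both have the same hydrogen-bond donor and acceptor counts. Nothing available accounts for the size of this step.

The linking atom and the halogens on the ring change together, so the step cannot be assigned to either change alone. The groups (3,4-dichlorophenyl)sulfanyl and 4-fluorophenoxy on the same carbon would separate the two, leaving open which part of the exchange carries the step.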